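Trifluoromethyl on the aryl ring across two cores

The source may hold more compounds than are shown below. What is called first, only, known or untested is meant among the compounds shown, and "the series" means these compounds.

Working notes on a small growth-inhibition series. Compound 1 `O=C1C=COC(/C=C/c2ccccc2)C1` carries a styryl arm on a pyranone-type core; in a functional assay on MCF7 cells (Homo sapiens) for inhibition, read by sulforhodamine B assay, with a stated time of 48 h (a lower number here means a stronger inhibitor of growth, a higher number a weaker inhibitor of growth), compound 1 gives 153 uM. Compound 2 `O=C1C=COC(/C=C/c2ccc(C(F)(F)F)cc2)C1` differs from it by one change, (trifluoromethyl in place of hydrogen on an aromatic carbon), and in this assay compound 2 gives 41.2 uM. That change made the step of a 3.7-fold lower number from compound 1 to compound 2 (0.57 log units; beyond the scatter).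

Compound 3 `O=C1C=CCC(/C=C/c2ccccc2)N1` keeps the same styryl arm on a different core; the difference between the two cores is not broken down here. In this assay compound 3 gives 607 uM, the highest number of the three measured, with compound 1 its nearest neighbour and compound 2 furthest from it.

Compound 4 `O=C1C=CCC(/C=C/c2ccccc2C(F)(F)F)N1` is not yet measured. It differs from compound 3 by trifluoromethyl in place of hydrogen on an aromatic carbon. For the measured compounds named here, this is the same kind of change as the one from compound 1 to compound 2, not the same: there the trifluoromethyl sits para to a group of 9 heavy atoms, here it sits ortho to a group of 9 heavy atoms, and the core is also not the same. Going by the values given here, the only measured instance of this kind of change is the step of a 3.7-fold lower number from compound 1 to compound 2 (0.57 log units; beyond the scatter); the effect of the placement and of the other core is unknown. The step from compound 3 to compound 4 is therefore estimated as a 2.4-fold lower number from compound 3 to compound 4 (0.39 log units; beyond the scatter), in the same direction as that measured step and somewhat smaller, because the parent compound 3 sits at 607 uM. For compound 4 the estimated value is 250 uM, within 90 uM to 650 uM.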

Compound 4, concentration for growth inhibition (reported as GI): 120 uM
Beside the measured number, compound 4's estimate is 2.1-fold (0.32 log units) above it, and the stated range covers the measured number.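

In this assay, trifluoromethyl in place of hydrogen on an aromatic carbon gives a 5.1-fold lower number from compound 3 to compound 4 (0.70 log units; beyond the scatter) and so moves the number the same way on the core of compound 3 as on the core of compound 1, with no difference between the two steps beyond the scatter: the same change on two cores in this assay, a 3.7-fold lower number (0.57 log units; beyond the scatter) from compound 1 to compound 2 and a 5.1-fold lower number (0.70 log units; beyond the scatter) from compound 3 to compound 4, 1.4-fold (0.13 log units) apart, within the scatter of two such steps. Within this series, then, the change carried over from one core to the other in direction and in approximate size, even with the trifluoromethyl of compound 4 ortho to a group of 9 heavy atoms and the trifluoromethyl of compound 2 placed differently on its ring. This does not show that core and placement have no influence, as the two steps differ in both at once and the two influences cannot be separated, and two steps set no general rule for other cores.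

The compounds shown leave open how trifluoromethyl would behave at one and the same place on the aromatic ring of both cores. They also leave open whether another group on that ring, such as a chlorine, a methoxy group, an amine or a carboxylic acid, would carry over between the cores in the same way.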